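The source may report more compounds than this note shows. Statements on the series, on what has been measured and on what is new or still open speak of the compounds shown alone.

For the measured compounds named here, compound 1 `O=C(Nc1cccc(Cl)c1)Nc1cccc(CNc2nccnc2Cl)c1` is the only compound here with a number in a functional assay on HepG2 cells (Homo sapiens) for antiproliferative activity, read by MTT assay, with a stated time of 48 h; a lower number here means a stronger inhibitor, a higher number a weaker inhibitor: compound 1 gives 9140 nM. Compound 2 `O=C(Nc1cccc(CNc2nccnc2Cl)c1)Nc1cccc2ccccc12` reaches only a limit of the assay in this assay, where compound 2 shows > 40000 nM, so that the limit of > 40000 nM in this assay, at which 1 of the 2 values shown sits, is all that is known of it. Compound 3 `Cc1ccc(NC(=O)Nc2cccc(CNc3nccnc3Cl)c2)cc1Cl` differs from compound 1 by methyl in place of hydrogen on an aromatic carbon. Going by the values given here, no step of that kind has been measured, so the change from compound 1 to compound 3 is expected to stay within the usual scatter, giving a 1.1-fold lower number from compound 1 to compound 3 (0.06 log units; within the scatter). Compound 3 is estimated at 8000 nM, between 3000 nM and 25000 nM.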

Compound 3, half-maximal inhibitory concentration: 11300 nM
Compound 3: middle estimate off by 1.4-fold (0.15 log units), on the low side, and the stated range covers the measured number.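

Methyl in place of hydrogen on an aromatic carbon, ortho to a chloro group, gives a 1.2-fold higher number from compound 1 to compound 3 (0.09 log units; within the scatter) in this assay. For the compounds shown here, this position therefore accepts one added methyl with no change that can be told apart from the spread of repeated measurements, something the earlier compounds could not show. Nothing measured here gives a reason for this result.

On these data alone, whether an amine, a methoxy group or a carboxylic acid at this position would behave like methyl remains open. Also open, as far as these compounds go, is how methyl would behave on a ring without the chloro group.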